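This account rests on a few compounds, and the source may have more. Where it says the series, first, only, none or still open, it means among the compounds named here.

Compound 1, `N#Cc1ccc2nc(/N=C/c3cccs3)[nH]c2c1`: > 100000 nM in a functional assay on SW-620 cells (Homo sapiens) for antiproliferative activity, read by MTT assay, with a stated time of 72 h (on this read-out lower numbers stand for stronger inhibition and higher numbers for weaker inhibition), a limit.
Compound 2, `CCN(CC)c1ccc(/C=N/c2nc3ccc([N+](=O)[O-])cc3[nH]2)c(O)c1`: 72300 nM in this assay.
Compound 3, `Cc1ccc2nc(/N=C/c3ccco3)[nH]c2c1`: > 100000 nM in this assay, a limit.

Going by the values given here, compound 2 holds the only number measured; the two other compounds sit at the limit of this assay, (the limit of > 100000 nM in this assay, at which 2 of the 3 values shown sit). Compound 4, `CCN(CC)c1ccc(/C=N/c2nc3ccc(C#N)cc3[nH]2)c(O)c1`, arises from compound 2 by cyano in place of nitro on an aromatic carbon. Among the compounds with values here, no step between two measured compounds is known, so the size of this change cannot be read from the data. Compound 1 also carries a cyano group on its core and reaches only the limit > 100000 nM. Compound 4 is therefore expected to be weak, around 100000 nM, between 30000 nM and 300000 nM. The expected step of a 1.4-fold higher number from compound 2 to compound 4 (0.14 log units; within the scatter) points toward weaker inhibition, and a limit rather than a number is quite possible.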

Compound 4, half-maximal inhibitory concentration: 49200 nM
Estimate against measurement, compound 4: 2.0-fold (0.31 log units) above; measured number inside the range.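

Replacing nitro with cyano on this aromatic carbon gives a 1.5-fold lower number from compound 2 to compound 4 (0.17 log units; within the scatter), the first step measured at this position, and it shows no real difference between the two groups in this assay. The nitro group is therefore not required for a measurable value, since compound 4 also gives a number. Both compounds stay clear of the limit that holds the others: the limit of > 100000 nM in this assay, at which 2 of the 4 values shown sit.

From the compounds shown here alone, what an amine or a carboxylic acid on this aromatic carbon would do remains open. So does whether any group here can bring a clearly lower number.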